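A few compounds are considered here, and "the series" means these few. Any claim that something is new, unique, unknown or untested is made for them only; others in the source may bear on it.

Compound 1 `CCc1ccccc1C1CC(c2ccc(O)cc2)=NN1C(=O)c1cccnc1` gives 35400 nM in an ADME assay on HepG2 cells (Homo sapiens) for cytotoxicity, read by MTT assay, with a stated time of 7 days (on this read-out lower numbers stand for stronger inhibition and higher numbers for weaker inhibition), and sits level, within the scatter, with compound 2 `O=C(c1cccnc1)N1N=C(c2ccc(O)cc2)CC1c1ccc(Br)cc1` at 58700 nM while compound 3 `O=C(c1cccnc1)N1N=C(c2ccc(O)cc2)CC1c1ccc(OCc2ccccc2)cc1` at 11400 nM lies clearly lower. Compound 4 `Cc1cc(C)c(C2CC(c3ccc(O)cc3)=NN2C(=O)c2cccnc2)c(C)c1` differs from compound 1 in a single group, with 2,4,6-trimethylphenyl in place of 2-ethylphenyl on a saturated ring carbon as the whole change. Going by the values given here, the only measured change at that carbon gave a 1.7-fold higher number from compound 1 to compound 2 (0.22 log units; within the scatter) and stayed small. The larger 5.1-fold lower number from compound 2 to compound 3 (0.71 log units; beyond the scatter) came with benzyloxy in place of bromo on an aromatic carbon, and compound 4 carries no benzyloxy. The step expected in this assay is therefore small, with a 1.1-fold lower number from compound 1 to compound 4 (0.04 log units; within the scatter) as the estimate and nothing beyond the scatter foreseen. For compound 4 the estimate is 32000 nM with 14000 nM to 70000 nM as the expected range.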

Compound 4, half-maximal inhibitory concentration: 54500 nM
Beside the measured number, compound 4's estimate is 1.7-fold (0.23 log units) below it; the measured number falls inside the stated range.
By their numbers in this assay, from the lowest: compound 3; then compounds 1, 4 and 2 (each within the scatter of the next).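

In this assay, 2,4,6-trimethylphenyl on the saturated ring carbon reads level with both earlier groups there, with a 1.5-fold higher number from compound 1 to compound 4 (0.19 log units; within the scatter) and a 1.1-fold lower number from compound 2 to compound 4 (0.03 log units; within the scatter). Across compounds 1, 2 and 4, then, swapping these groups leaves the number within the scatter, while compound 3, with its benzyloxy group, goes against this pattern. No measured evidence here accounts for this. Still open, on these data alone, is whether an amine or a carboxylic acid at this carbon would stay level as well or shift the number as compound 3 does.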